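A second fluorine on the hydrazone ring: expected effect

This account rests on a few compounds, and the source may have more. Where it says the series, first, only, none or still open, it means among the compounds named here.

Three related compounds have been tested in an ADME assay on HT-29 cells (Homo sapiens) for inhibition, read by MTT assay, with a stated time of 72 h; a higher number here means a weaker inhibitor, a lower number a stronger inhibitor. Compound 1 `C=CC(=O)Nc1cccc(Nc2nc(N/N=C/c3ccc(F)cc3F)ncc2Cl)c1` gives 4760 nM. Compound 2 `CN(C)C/C=C/C(=O)Nc1cccc(Nc2nc(N/N=C/c3ccccc3F)ncc2Cl)c1` gives 3660 nM. Compound 3 `CN(C)C/C=C/C(=O)Nc1cccc(Nc2nc(N/N=C/c3ccc(F)cc3)ncc2Cl)c1` gives 3300 nM, the lowest of the three numbers, but its gaps to compound 2 and compound 1 both lie within the scatter of repeated measurements, so no order among them can be claimed.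

Compound 4 `CN(C)C/C=C/C(=O)Nc1cccc(Nc2nc(N/N=C/c3ccc(F)cc3F)ncc2Cl)c1` has not yet been measured. It differs from compound 3 by fluoro in place of hydrogen on an aromatic carbon; seen one bond further out, a 4-fluorophenyl becomes a 2,4-difluorophenyl.

Going by the values given here, the one measured step that bears on this is the move of a single fluoro across the same ring, a 1.1-fold lower number from compound 2 to compound 3 (0.04 log units; within the scatter), which was within the scatter. Compound 1 carries the same 2,4-difluorophenyl as compound 4, but on a different amide, so it gives only a hint, and its number sits close to the others. Adding a second fluoro is therefore expected to leave this assay essentially unchanged: the estimated step of a 1.2-fold higher number from compound 3 to compound 4 (0.06 log units; within the scatter) should stay within the scatter. For compound 4 the estimated value is 3800 nM, with a range from 1900 nM to 7600 nM.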

Compound 4, half-maximal inhibitory concentration: 2920 nM
Estimate against measurement, compound 4: 1.3-fold (0.11 log units) above; measured number inside the range.
By their numbers in this assay, from the lowest: compounds 4, 3, 2 and 1 (each within the scatter of the next).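

In this assay, fluoro in place of hydrogen on the aromatic carbon ortho to a large group gives a 1.1-fold lower number from compound 3 to compound 4 (0.05 log units; within the scatter), so filling this position produces no change that can be told apart from measurement noise. Until now the evidence covered only a single fluoro moved around the ring, whereas the step of a 1.3-fold lower number from compound 2 to compound 4 (0.10 log units; within the scatter) adds a second fluoro from the other side, and again the single-fluoro and 2,4-difluorophenyl compounds cannot be separated. Going by these compounds alone, compound 4 also gives the first clean comparison of the two amides with the ring held constant: 3-(dimethylamino)prop-1-en-1-yl in place of vinyl on the carbonyl carbon gives a 1.6-fold lower number from compound 1 to compound 4 (0.21 log units; within the scatter), so this change cannot be separated from the scatter either.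

All the ring changes shown involve only hydrogen and fluoro, leaving open whether a larger or different group at this position, such as a methoxy group or a carboxylic acid, would shift the number beyond the scatter. Nothing available here offers an explanation for how small these steps are.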